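Bicyclic tertiary amine in place of the primary amine

This account rests on a few compounds, and the source may have more. Where it says the series, first, only, none or still open, it means among the compounds named here.

Compound 3 `Nc1ccc2cc(NC(=O)CCc3ccc(C(F)(F)F)cc3)ccc2n1` gives 240 nM in an assay on isolated protein for displacement of a labelled ligand from melanin-concentrating hormone receptor 1 (Homo sapiens) (on this read-out higher numbers stand for weaker inhibition and lower numbers for stronger inhibition), the second highest of the three numbers: compound 2 `CCCN(CCC)c1ccc2cc(NC(=O)CCc3ccc(C(F)(F)F)cc3)ccc2n1` gives 490 nM and compound 1 `CC(C)N(C)c1ccc2cc(NC(=O)CCc3ccc(C(F)(F)F)cc3)ccc2n1` gives 2 nM. Compound 4 `O=C(CCc1ccc(C(F)(F)F)cc1)Nc1ccc2nc(N3CC4CCC3C4)ccc2c1` differs from compound 3 by a group of 7 heavy atoms (6 carbon, 1 nitrogen; one five-membered non-aromatic ring of carbon only, one five-membered non-aromatic ring with 1 hetero atom) in place of one nitrogen atom, on an aromatic carbon. Among the measured compounds shown here, two measured steps bear on this carbon: a 120-fold higher number from compound 1 to compound 3 (2.08 log units; beyond the scatter), whereas a 2.0-fold lower number from compound 2 to compound 3 (0.31 log units; beyond the scatter). A small branched tertiary amine thus gives far stronger inhibition than the primary amine, while dipropylamino gives a modestly weaker one. The entering group is tertiary and ring-constrained, closer in size to the group of compound 1 than to dipropylamino, so a clearly lower number is expected in this assay, though uncertain in extent. Compound 4 is estimated at 20 nM, range 3 nM to 150 nM. The expected step is a 12-fold lower number from compound 3 to compound 4 (1.08 log units; beyond the scatter).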

Compound 4, half-maximal inhibitory concentration: 1 nM
Compound 4: the middle estimate sits 20-fold (1.30 log units) above what was measured; measured number outside the range, below it.
By their numbers in this assay, from the lowest: compounds 4 and 1 (each within the scatter of the next); then compound 3; then compound 2.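

In this assay, the bicyclic tertiary amine gives a 240-fold lower number from compound 3 to compound 4 (2.38 log units; beyond the scatter) and a 490-fold lower number from compound 2 to compound 4 (2.69 log units; beyond the scatter), so at this aromatic carbon, two groups of 7 heavy atoms can lie far apart and heavy-atom count alone does not set the number. The step of a 2.0-fold lower number from compound 1 to compound 4 (0.30 log units; within the scatter) is within the scatter, so the larger bicyclic group and isopropyl(methyl)amino cannot be told apart here. Nothing available explains these differences. Open, as far as these compounds go, is whether dimethylamino, pyrrolidin-1-yl or piperidin-1-yl on this carbon would stay level with compound 1 or fall back towards compound 2.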